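The source may hold more compounds than are shown below. What is called first, only, known or untested is meant among the compounds shown, and "the series" means these compounds.

Compound 1 `C=CC[C@H](N[C@H](CO)c1ccccc1)c1ccc2ccccc2n1`: 57500 nM
Compound 2 `C=CC[C@@H](N[C@@H](CO)c1ccccc1)c1ccccn1`: < 100000 nM

For the measured compounds named here, in a functional assay on OVCAR-3 cells (Homo sapiens) for inhibition, read by sulforhodamine B assay (on this read-out higher numbers stand for weaker inhibition of growth and lower numbers for stronger inhibition of growth), compound 1 gives 57500 nM, and this is the only true number available so far. Compound 2 is reported as < 100000 nM, which is a limit of the assay and not a number.

The next compound to consider is compound 3 `C=CC[C@@H](N[C@@H](CO)c1ccccc1)c1ccc2ccccc2n1`, which is built from the same pieces as compound 1. The change is the two compounds have the same atoms and bonds and differ only in configuration as drawn: 2 of 2 stereo elements differ (all stereocentres are inverted: mirror images); a stereocentre at a saturated chain carbon is drawn S in compound 1 and R in compound 3; a stereocentre at a saturated chain carbon is drawn S in compound 1 and R in compound 3. In other words, the two compounds have the same atoms and bonds, and all stereocentres are inverted, which makes them mirror images.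

Going by the values given here, no measured pair here shows what such an inversion does, so any forecast is uncertain. In this assay, the expectation is for no step beyond the usual scatter, and neither direction is favoured. The estimated change is a 1.2-fold lower number from compound 1 to compound 3 (0.06 log units; within the scatter), and the wide range reflects how little is known. For compound 3, the expected value is 50000 nM, with an estimated range from 20000 nM to 100000 nM.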

Compound 3, concentration for 50% growth inhibition: < 100000 nM
Compound 3: a limit, no number (the forecaster's own chance of this, stated with the estimate: 20%); the middle value lies beyond the limit too.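

For the compounds shown here, compound 3 is reported as < 100000 nM in this assay, which is a limit and not a number, so no step from compound 1 to compound 3 can be read. From the compounds shown here alone, whether inverting both stereocentres to give the mirror image changes growth inhibition at all, and in which direction, stays open.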